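Working notes: double-bond configuration, compound 2 to compound 3

A few compounds are considered here, and "the series" means these few. Any claim that something is new, unique, unknown or untested is made for them only; others in the source may bear on it.

In a physicochemical assay for lipophilicity (a higher number here means a more lipophilic compound, a lower number a more polar compound), compound 1 (`CC/C=C(\CC)C(=O)O`) gives 2.06 and compound 2 (`C/C=C/C(=C\CC)C(=O)O`) gives 2.22 so far, and these two numbers lie within the scatter of each other. Within the data shown here, the single measured step is a number 0.16 log units higher from compound 1 to compound 2 (within the scatter) for prop-1-en-1-yl in place of ethyl on a double-bonded chain carbon bound to a carbonyl carbon and a double-bonded chain carbon.

Compound 3 (`C/C=C\C(=C/CC)C(=O)O`) is the next to be measured. Its relation to compound 2 reads as follows: the two compounds have the same atoms and bonds and differ only in configuration as drawn: 1 of 2 stereo elements differ; a double bond is drawn E in compound 2 and Z in compound 3 and no group leaves or enters.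

Among the measured compounds shown here, the measured step exchanged a group and left the configuration alone, so no measured pair isolates a change of configuration. For the measured compounds named here, it is the only guide available, and it stayed within the scatter. Taking compound 2 at 2.22 as the anchor, no step beyond the scatter is expected in this assay. The expected change is a number 0.02 log units lower from compound 2 to compound 3 (within the scatter) and so carries no clear direction. For compound 3 the estimate is 2.2 with an expected range from 1.9 to 2.5 as its ends.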

Compound 3, partition coefficient: 2.22
Estimate against measurement, compound 3: 0.02 log units below; measured number inside the range.
By their numbers in this assay, from the lowest: compounds 1, 2 and 3 (each within the scatter of the next).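

Among these compounds, a change of configuration is isolated here for the first time, and in this assay it reads as no change at the digits printed from compound 2 to compound 3 (within the scatter). This step can be assigned to configuration alone because nothing else separates the two structures: the fact that compounds 2 and 3 differ only in the configuration as drawn. The exchange of ethyl for prop-1-en-1-yl now also appears with the other drawn configuration, as a number 0.16 log units higher from compound 1 to compound 3 (within the scatter), so across these three compounds neither the group exchange nor the change from E to Z on this double bond gives a step beyond the scatter.

Among the compounds shown here, the second stereo element has not yet been seen to change on its own, so whether it would behave in the same way remains open. From the compounds shown here alone, it is also open whether a longer chain such as butyl in place of ethyl, or a methyl ester or primary amide in place of the carboxylic acid, would give a step beyond the scatter in this assay.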